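The source may report more compounds than this note shows. Statements on the series, on what has been measured and on what is new or still open speak of the compounds shown alone.

Measured so far:
Compound 1, `C=CCNC(=O)/C(C)=C(/C)c1ccc(Cl)cc1`: 400 mg/kg
Compound 2, `C=CCNC(=O)/C(C)=C(/C)c1ccccc1`: 400 mg/kg

Both numbers come from a toxicity assay on the whole organism (strain Icem-CET (SPF Caw)) for cytotoxicity, with Mus musculus as the target (a lower number here means that less compound is needed, a higher number that more compound is needed for the effect), a whole-animal test in mice. Among the compounds with values here, on these numbers compound 2 stands level with compound 1, and the only measured step in this small set, no change at the digits printed from compound 1 to compound 2 (within the scatter), shows that swapping a chloro substituent for a hydrogen on the aromatic ring left the read-out where it was.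

The next compound, compound 3, `C=CCNC(=O)/C(C)=C(/C)c1ccc(C)cc1`, differs from compound 2 in one place: methyl in place of hydrogen on an aromatic carbon. Within the data shown here, the single step that bears on this change is the one from compound 1 to compound 2, where exchanging one small substituent at this same aromatic position for another produced no shift beyond the scatter. Since that exchange, which removed a halogen entirely, did nothing measurable, a methyl entering at the same spot is expected to behave alike, giving a step of no change at the digits printed from compound 2 to compound 3 (within the scatter) that stays within the usual spread of repeated runs.

Compound 3 is therefore estimated at 400 mg/kg in this assay, with a likely range from 200 mg/kg to 800 mg/kg.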

Compound 3, dose for half-maximal effect: 400 mg/kg
Compound 3: middle estimate and measured number agree at the digits printed; the range from low to high includes it.
By their numbers in this assay, from the lowest: compounds 1, 2 and 3 (each within the scatter of the next).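

Within the data shown here, until now, the only change at this spot on the aromatic ring was the loss of a chloro group, whereas here a carbon group enters in place of hydrogen. In this assay, placing a methyl on this aromatic carbon, para to a large group, gives no change at the digits printed from compound 2 to compound 3 (within the scatter) and exchanging chloro directly for methyl gives no change at the digits printed from compound 1 to compound 3 (within the scatter), so hydrogen, chloro and methyl now form a set of three that this read-out cannot tell apart at this position. Nothing measured here explains why these three exchanges leave the number in place.

The compounds shown leave open whether a different kind of group at this position, such as an amine, a carboxylic acid or a longer chain, would move the number beyond the scatter. They also leave open whether a change elsewhere in the shared core, for instance at the amide hydrogen, would do so.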